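Nitro for trifluoromethyl on a benzylic aryl ring

A few compounds are considered here, and "the series" means these few. Any claim that something is new, unique, unknown or untested is made for them only; others in the source may bear on it.

Measured compounds:
compound 1 `N/C(=N\O)c1ccc(C2=C(S(=O)(=O)c3ccc(F)cc3)CC3(CCCCC3)O2)cc1` gives 92900 nM in an ADME assay on cells (Peritoneal macrophage, Mus musculus, strain Balb/c) for cytotoxicity, read by resazurin assay, with a stated time of 72 h; a lower number here means that less compound is tolerated, a higher number that more compound is tolerated;
compound 2 `CC1(Cc2ccc(/C(N)=N/O)cc2)CC(S(=O)(=O)c2ccc(F)cc2)=C(c2ccc(/C(N)=N/O)cc2)O1` gives 42200 nM in this assay;
compound 3 `CC1(Cc2ccc(C(F)(F)F)cc2)CC(S(=O)(=O)c2ccc(F)cc2)=C(c2ccc(/C(N)=N/O)cc2)O1` gives 103000 nM in this assay.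

Compound 3 shows the highest of the three numbers, though its gap to compound 1 lies within the scatter; only compound 2 stands clearly apart, the step of a 2.4-fold higher number from compound 2 to compound 3 (0.39 log units; beyond the scatter) being beyond the scatter. Compound 4 `CC1(Cc2ccc([N+](=O)[O-])cc2)CC(S(=O)(=O)c2ccc(F)cc2)=C(c2ccc(/C(N)=N/O)cc2)O1` has not yet been measured. It differs from compound 3 by nitro in place of trifluoromethyl on an aromatic carbon. Among the compounds with values here, the only measured step touching this position is a 2.4-fold higher number from compound 2 to compound 3 (0.39 log units; beyond the scatter), in which trifluoromethyl entered on that aromatic carbon; it was modest. Within the data shown here, no measured pair shows nitro in place of trifluoromethyl, so the direction is open. Given that the one change at this position moved the number only modestly, compound 4 is expected to stay near compound 3, with a step of a 1.3-fold lower number from compound 3 to compound 4 (0.11 log units; within the scatter) no larger than the scatter. Compound 4 is therefore estimated at 80000 nM, ranging from 35000 nM to 180000 nM.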

Compound 4, half-maximal cytotoxic concentration: 97400 nM
For compound 4 the middle estimate is 1.2-fold (0.09 log units) below the measured one; the range from low to high includes it.
By their numbers in this assay, from the lowest: compound 2; then compounds 1, 4 and 3 (each within the scatter of the next).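

In this assay, nitro in place of trifluoromethyl on this aromatic carbon gives a 1.1-fold lower number from compound 3 to compound 4 (0.02 log units; within the scatter), so this direct exchange leaves the number within the scatter. The group at this position in compound 2 is now replaced in two ways, with a 2.4-fold higher number from compound 2 to compound 3 (0.39 log units; beyond the scatter) and a 2.3-fold higher number from compound 2 to compound 4 (0.36 log units; beyond the scatter), and both steps lie beyond the scatter in the same direction. Nothing available explains why these two groups read alike or why compound 2 stands apart from them.

The compounds shown leave open whether an amine or a carboxylic acid on this aromatic carbon would stay with compound 3 and compound 4 or fall nearer compound 2. They also leave open whether the exchange of trifluoromethyl for nitro would read the same on a longer chain than the benzyl link.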